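Chain-linked ring swap on an alkyne-bearing nucleoside core

A few compounds are considered here, and "the series" means these few. Any claim that something is new, unique, unknown or untested is made for them only; others in the source may bear on it.

Compound 2 `NC(=O)c1ncn(C2O[C@H](CO)[C@@H](O)[C@H]2O)c1C#CCC1CCCC1` and compound 1 `NC(=O)c1ncn(C2O[C@H](CO)[C@@H](O)[C@H]2O)c1C#CC1CCCCC1` share one core and differ only at the triple-bonded carbon. In a functional assay on L1210 cells (Mus musculus) for inhibition, tested at 100 ug/mL (on this read-out higher numbers stand for more inhibition at the one concentration tested (going by the name of the read-out) and lower numbers for less inhibition), compound 1 gives 18.9%, while compound 2 gives -10.7%, so compound 2 holds the lower of the two numbers; the step from one to the other is a number 29.6 percentage points lower from compound 1 to compound 2 (beyond the scatter). Compound 3 `NC(=O)c1ncn(C2O[C@H](CO)[C@@H](O)[C@H]2O)c1C#CCCc1ccccc1` is now to be measured in this assay. The change from compound 2 to compound 3 is benzyl in place of cyclopentyl on a saturated chain carbon bound to a triple-bonded carbon. Among the compounds with values here, no measured step covers this change: the single step known concerns cyclohexyl against cyclopentylmethyl on the triple-bonded carbon, and it shows only that moving from compound 1 to compound 2 lowered the number by a modest amount beyond the scatter. That ring change does not tell how a benzyl in place of cyclopentyl on the saturated chain carbon will behave. The expectation for compound 3 is therefore a small step of a number 15.7 percentage points higher from compound 2 to compound 3 (beyond the scatter), with wide uncertainty. Compound 3 is estimated at 5%, within a range from -20% to 30%.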

Compound 3, a percentage reported as inhibition, at one concentration (the size of the read-out at that concentration, not a potency): 8.5%
The estimate for compound 3 lay 3.5 percentage points below the measured number; the range from low to high includes it.
By their numbers in this assay, from the lowest: compound 2; then compound 3; then compound 1.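

In this assay, the change from a cyclopentyl to a benzyl on a saturated chain carbon bound to a triple-bonded carbon gives a number 19.2 percentage points higher from compound 2 to compound 3 (beyond the scatter), showing that the number at this position depends on which ring the chain carries and not only on the presence of a ring. The comparison with the directly attached ring now has a second partner: phenethyl in place of cyclohexyl on a triple-bonded carbon gives a number 10.4 percentage points lower from compound 1 to compound 3 (beyond the scatter), so in these three compounds neither chain-linked ring reaches the number of compound 1, although the phenethyl group recovers part of the gap left by the cyclopentylmethyl group. Nothing available explains either step.

The compounds shown leave open whether a phenyl on the triple-bonded carbon, a longer chain carrying the phenyl, or an amine or a carboxylic acid in place of the ring would match or pass compound 1. With a single concentration behind each number, they also leave open how these compounds would compare in potency on these cells.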